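A few compounds are considered here, and "the series" means these few. Any claim that something is new, unique, unknown or untested is made for them only; others in the source may bear on it.

Working notes on the series, read out in a functional assay on MDA-MB-231 cells (Homo sapiens) for antiproliferative activity, read by MTT assay, with a stated time of 24 h; a lower number here means a stronger inhibitor, a higher number a weaker inhibitor. Compound 1 (`O=C(NNc1cccc(Cl)c1)c1ccc(NS(=O)(=O)c2cnc(O)nc2O)cc1`) gives 17400 nM and compound 3 (`CCCCOc1ccc(C(=O)NNC(=O)c2ccc(NS(=O)(=O)c3cnc(O)nc3O)cc2)cc1`) gives 11900 nM, two values within the scatter of each other. Compound 2 (`O=C(NNc1ccccc1F)c1ccccc1NS(=O)(=O)c1cnc(O)nc1O`) gives > 20000 nM, which is a limit of the assay and not a number. Going by the values given here, compound 3 therefore stands level with compound 1, and these are the only two numbers so far.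

In compound 4 (`O=C(NNC(=O)c1ccccc1F)c1ccc(NS(=O)(=O)c2cnc(O)nc2O)cc1`), 2-fluorophenyl replaces 4-butoxyphenyl on a carbonyl carbon (2-fluorophenyl in place of 4-butoxyphenyl on a carbonyl carbon). Among the compounds with values here, no measured pair shows this change, so the expectation rests on the values alone. In this assay, a small move toward weaker inhibition is expected, possibly none beyond the scatter. The reference here is compound 1, which has no butoxy chain and gives 17400 nM in the same read-out. A reading at the assay limit also remains possible for compound 4. The estimated change is a 1.4-fold higher number from compound 3 to compound 4 (0.15 log units; within the scatter) as a modest step. For compound 4 the expected value is 17000 nM, with an estimated range from 10000 nM to 30000 nM in this assay.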

Compound 4, half-maximal inhibitory concentration: > 20000 nM
Compound 4 gave a limit, no number; the forecaster's own chance of this, stated with the estimate: 35%; middle value at least 1.1-fold (0.07 log units) away from the limit.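

The series now holds its first steps at this place: on the carbonyl carbon in this assay, 2-fluorophenyl in place of 4-butoxyphenyl gives an at least 1.6-fold higher number from compound 3 to compound 4 (0.22 log units; that floor lies within the scatter) and leaves no measurable number. The second step, (2-fluorophenyl)carbonyl in place of 3-chlorophenyl on an amine nitrogen, gives an at least 1.1-fold higher number from compound 1 to compound 4 (0.06 log units; that floor lies within the scatter) and likewise fixes only a lower bound on the size of the change. From the compounds shown here alone, compound 4 gives a limit and not a number, so both steps are floors that cannot be told apart from no change, their true size stays unknown, and such limits are frequent in this small set: the limit of > 20000 nM in this assay, at which 2 of the 4 values shown sit.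

Going by these compounds, how far compound 4 lies past the limit stays open, and this single change cannot separate the loss of the butoxy chain from the entry of the fluorine. On these data alone, whether a hexyloxy chain, an amine or a carboxylic acid in place of the butoxy chain on that phenyl ring would give a number inside the measurable range also remains open.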